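The source may report more compounds than this note shows. Statements on the series, on what has been measured and on what is new or still open speak of the compounds shown alone.

Measured so far:
Compound 1 `COC(=O)/C=C/c1cccc(N(Cc2ccccc2)C(=O)C2CCCCC2)c1`: in an assay on isolated protein with Bile acid receptor (Homo sapiens) as the target (a higher number here means that more compound is needed for the effect, a lower number that less compound is needed), compound 1 gives > 1000 nM, which is a limit of the assay and not a number.
Compound 2 `COC(=O)/C=C/c1cccc(N(Cc2ccc(-c3cccc(C(C)=O)c3)cc2)C(=O)C2CCCCC2)c1`: compound 2 gives 227 nM in this assay.
Compound 3 `COC(=O)/C=C/c1cccc(N(Cc2ccc(/C=C/c3ccc(F)cc3)cc2)C(=O)C2CCCCC2)c1`: compound 3 gives 185 nM in this assay.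

Compound 3 holds the lowest of the two numbers shown; its nearest neighbour is compound 2, and the step of a 1.2-fold lower number from compound 2 to compound 3 (0.09 log units; within the scatter) lies within the scatter. Compound 4 `COC(=O)/C=C/c1cccc(N(Cc2ccc(-c3cccc(OC(F)(F)F)c3)cc2)C(=O)C2CCCCC2)c1` differs from compound 3 by 3-(trifluoromethoxy)phenyl in place of 2-(4-fluorophenyl)ethenyl on an aromatic carbon. Within the data shown here, two measured steps bear on this: an at least 4.4-fold lower number from compound 1 to compound 2 (0.64 log units; beyond the scatter) and an at least 5.4-fold lower number from compound 1 to compound 3 (0.73 log units; beyond the scatter), each at least modest once a larger group replaces hydrogen at that carbon, while the swap between the two groups in a 1.2-fold lower number from compound 2 to compound 3 (0.09 log units; within the scatter) stayed within the scatter. Compound 4 keeps a substituted phenyl at the same carbon, so the step of a 1.2-fold higher number from compound 3 to compound 4 (0.09 log units; within the scatter) is expected to stay within the scatter. Compound 4 is estimated at 230 nM in this assay, between 90 nM and 600 nM.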

Compound 4, half-maximal effective concentration: 420 nM
The estimate for compound 4 lay 1.8-fold (0.26 log units) below the measured number; the measured number falls inside the stated range.
By their numbers in this assay, from the lowest: compounds 3, 2 and 4 (each within the scatter of the next, the first and the last beyond it). At a limit, above all of these: compound 1.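

In this assay, a swap between large groups at this carbon now moves the number beyond the scatter: a 2.3-fold higher number from compound 3 to compound 4 (0.36 log units; beyond the scatter). By contrast, a 1.9-fold higher number from compound 2 to compound 4 (0.27 log units; within the scatter) stays within the scatter, so trifluoromethoxy and acetyl on the added phenyl cannot be told apart here. All three large groups shown still lower the number relative to hydrogen, with an at least 2.3-fold lower number from compound 1 to compound 4 (0.37 log units; beyond the scatter), but this step starts from a limit of the assay and not a number: the limit of > 1000 nM in this assay, at which 1 of the 4 values shown sits.

On these data alone, compound 4 loses both the ethenyl link and the fluorine of compound 3 in one step, and which of the two matters remains open. Also open, as far as these compounds go, is how an amine or a carboxylic acid on the added phenyl would read.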